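The compounds below may be only part of what the source reports. "The series", "measured", "known", "first", "only" and "open" are said of these compounds alone.

Measured in a functional assay on TSGH cells (Homo sapiens) for inhibition, with a stated time of 72 h; on this read-out lower numbers stand for stronger inhibition and higher numbers for weaker inhibition:
- compound 1 `COc1cc(C(=O)c2cccc3[nH]ccc23)cc(OC)c1OC`: 54.4 nM
- compound 2 `COc1cc(C(=O)c2ccc3[nH]ccc3c2)cc(OC)c1OC`: 103 nM
- compound 3 `COc1cc(C(=O)c2cccc3cc[nH]c23)cc(OC)c1OC`: 310 nM

In this assay, compound 2 at 103 nM lies within the usual scatter of compound 1, while compound 3 has a higher number, beyond the scatter. Compound 4 `CCCn1ccc2cc(C(=O)c3cc(OC)c(OC)c(OC)c3)ccc21` has propyl in place of hydrogen on an aromatic nitrogen of compound 2 (propyl in place of hydrogen on an aromatic nitrogen). For the measured compounds named here, all three measured compounds keep that hydrogen, so the data contain no direct precedent for this change. A moderate move towards weaker inhibition, probably beyond the scatter, is therefore expected, though with wide uncertainty. The estimated change is a 2.9-fold higher number from compound 2 to compound 4 (0.46 log units; beyond the scatter). The expected value for compound 4 is 300 nM, within an estimated range of 70 nM to 1500 nM.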

Compound 4, half-maximal inhibitory concentration: 1500 nM
Beside the measured number, compound 4's estimate is 5.0-fold (0.70 log units) below it; low and high end bracket the measured number.
By their numbers in this assay, from the lowest: compounds 1 and 2 (each within the scatter of the next); then compound 3; then compound 4.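

Compound 4 is the first compound shown in which the hydrogen on the aromatic nitrogen is replaced, and in this assay the propyl group gives a 15-fold higher number from compound 2 to compound 4 (1.16 log units; beyond the scatter). This large step shows that the read-out at this position is sensitive to this change, moving towards much weaker inhibition. Nothing available explains the step.

The compounds shown leave open whether a methyl or ethyl group on the same nitrogen would give a smaller step, and whether a longer chain ending in an amine would behave like propyl. They also leave open whether the same change would give a similar step on compound 1 or compound 3.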